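Series notes: from compound 3 to compound 4

The source may hold more compounds than are shown below. What is called first, only, known or untested is meant among the compounds shown, and "the series" means these compounds.

Measured so far in a functional assay on MDA-MB-231 cells (Homo sapiens) for inhibition, read by MTT assay, with a stated time of 48 h (a higher number here means a weaker inhibitor of growth, a lower number a stronger inhibitor of growth), are:
- compound 1 `S=C(NCc1ccccc1)Nc1ccc2ncnc(Nc3ccc(Oc4ccccc4)cc3)c2c1` with 6800 nM
- compound 2 `NS(=O)(=O)c1ccc(NC(=S)Nc2ccc3ncnc(Nc4cccc(Br)c4)c3c2)cc1` with > 30000 nM (a limit)
- compound 3 `O=S(=O)(Nc1nccs1)c1ccc(NC(=S)Nc2ccc3ncnc(Nc4cccc(Br)c4)c3c2)cc1` with > 30000 nM (a limit)

Compound 3 stands only at a limit (> 30000 nM) and offers no number to start from. This is the limit of > 30000 nM in this assay, at which 2 of the 3 values shown sit, and compound 2 shares it.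

Compound 4 `FC(F)(F)c1ccc(NC(=S)Nc2ccc3ncnc(Nc4cccc(Br)c4)c3c2)cc1` carries trifluoromethyl in place of (1,3-thiazol-2-yl)sulfamoyl on an aromatic carbon, para to a large group (trifluoromethyl in place of (1,3-thiazol-2-yl)sulfamoyl on an aromatic carbon). For the measured compounds named here, the one measured step (a step that the two limits leave unreadable from compound 2 to compound 3) alters the same substituent but gives no size to carry over. Going by the values given here, with the only number held by compound 1 at 6800 nM as a guide, a step toward stronger growth inhibition is expected in this assay but its size is uncertain. A further limit remains possible. The expected change is an at least 2.5-fold lower number from compound 3 to compound 4 (0.39 log units; beyond the scatter) and is an estimate only. For compound 4 the estimate is 12000 nM and the expected range runs from 4000 nM to 30000 nM in the same read-out.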

Compound 4, concentration for 50% growth inhibition: 12200 nM
Estimate against measurement, compound 4: 1.0-fold (0.01 log units) below; low and high end bracket the measured number.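

Of the compounds that differ only at this aromatic carbon, para to a large group, compound 4 alone gives a number rather than a limit in this assay, so growth inhibition in this series responds to the substituent at this place. Trifluoromethyl in place of (1,3-thiazol-2-yl)sulfamoyl gives an at least 2.4-fold lower number from compound 3 to compound 4 (0.39 log units; beyond the scatter), and trifluoromethyl in place of sulfamoyl gives an at least 2.4-fold lower number from compound 2 to compound 4 (0.39 log units; beyond the scatter). Both steps are only minimum sizes, as compound 2 and compound 3 stand at a limit of the assay: the limit of > 30000 nM in this assay, at which 2 of the 4 values shown sit.

Going by these compounds, the true size of either step stays open, as does whether the difference comes from the loss of the sulfonamide or from trifluoromethyl itself. On these data alone, how a nitrile, a carboxylic acid or a methyl group at this aromatic carbon would compare with trifluoromethyl also remains unknown.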